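A few compounds are considered here, and "the series" means these few. Any claim that something is new, unique, unknown or untested is made for them only; others in the source may bear on it.

Compound 1, `NC1=NC2(CCOCC2)N(OCCCOc2cccc(Cl)c2Cl)C(N)=N1`: 100 nM in a functional assay on A549 cells (Homo sapiens) for antiproliferative activity, read by MTT assay, with a stated time of 72 h; on this read-out higher numbers stand for weaker inhibition and lower numbers for stronger inhibition
Compound 2, `NC1=NC2(CCOCC2)N(OCCCOc2ccccc2Cl)C(N)=N1`: 2700 nM in this assay

Compound 2 stands highest of the two numbers in this assay; its nearest neighbour is compound 1, reached by a 27-fold higher number from compound 1 to compound 2 (1.43 log units; beyond the scatter). Compound 3, `NC1=NC2(CCOCC2)N(OCCCOc2ccccc2)C(N)=N1`, is not yet measured. It differs from compound 2 by hydrogen in place of chloro on an aromatic carbon. Among the compounds with values here, the one measured step that bears on this is the move from compound 1 to compound 2, which also removed a chloro from the same aromatic ring and gave a 27-fold higher number from compound 1 to compound 2 (1.43 log units; beyond the scatter), a large loss of potency well beyond the scatter. Removing the remaining chloro is therefore expected to shift the number in the same direction, though its size is not fixed by a single precedent. The step to compound 3 is estimated at a 3.0-fold higher number from compound 2 to compound 3 (0.47 log units; beyond the scatter), and compound 3 is expected to give about 8000 nM, within a range of 2000 nM to 40000 nM.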

Compound 3, half-maximal inhibitory concentration: 1080 nM
For compound 3 the middle estimate is 7.4-fold (0.87 log units) above the measured one; the measured number lies below the stated range.
By their numbers in this assay, from the lowest: compound 1; then compound 3; then compound 2.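

In this assay, hydrogen in place of chloro on this aromatic carbon gives a 2.5-fold lower number from compound 2 to compound 3 (0.40 log units; beyond the scatter), so the change runs opposite to the earlier 27-fold higher number from compound 1 to compound 2 (1.43 log units; beyond the scatter), although both steps remove a chloro from the same ring. The effect of removing a chloro therefore depends on which chloro goes and on what else the ring carries, and the 2-chlorophenyl of compound 2 gives a higher number than the plain phenyl of compound 3. Even so, phenyl in place of 2,3-dichlorophenyl still gives an 11-fold higher number from compound 1 to compound 3 (1.03 log units; beyond the scatter), leaving compound 1 the most potent of the three, and nothing available explains this reversal.

As far as these compounds go, whether fluoro or methyl on this carbon would track with chloro or with hydrogen remains open. So does whether a longer chain to the phenoxy group would keep these differences.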